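A few compounds are considered here, and "the series" means these few. Any claim that something is new, unique, unknown or untested is made for them only; others in the source may bear on it.

Measured so far in an ADME assay on cells (Hepatocyte, Homo sapiens) for pharmacokinetics, read by LC-MS, with a stated time of 90 min, tested at 1 uM; on this read-out lower numbers stand for slow clearance and higher numbers for fast clearance:

Compound 1 `CN(C)c1ccc(Nc2c(NCCCCCC(=O)NO)c(=O)c2=O)cc1` gives < 5 uL/min; this is a limit of the assay.
Compound 2 `COc1ccc(Nc2c(NCCCCCC(=O)NO)c(=O)c2=O)cc1` gives < 4.7 uL/min; this is a limit of the assay.
Compound 3 `COc1ccc(Nc2c(NC(C)CCCCC(=O)NO)c(=O)c2=O)cc1` gives 7.1 uL/min.

The two cores differ by dimethylamino in place of methoxy on an aromatic carbon. With both values sitting at limits, namely the limit of < 5 uL/min in this assay, at which 1 of the 3 values shown sits, and (the limit of < 4.7 uL/min in this assay, at which 1 of the 3 values shown sits), the step that the two limits leave unreadable from compound 1 to compound 2 cannot be sized. From compound 2 to compound 3 the change methyl in place of hydrogen on a saturated chain carbon bound to a nitrogen on an aromatic ring and a saturated chain carbon gives an at least 1.5-fold higher number from compound 2 to compound 3 (0.17 log units; that floor lies within the scatter) in this assay.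

Compound 4 `C[C@H](CCCCC(=O)NO)Nc1c(Nc2ccc(N(C)C)cc2)c(=O)c1=O` is not yet measured. It carries the same change from compound 1, (methyl in place of hydrogen on a saturated chain carbon bound to a nitrogen on an aromatic ring and a saturated chain carbon), the place being identical in both cases. For compound 4 the expected step is an at least 1.5-fold higher number from compound 1 to compound 4 (0.17 log units; that floor lies within the scatter). This expectation rests on an at least 1.5-fold higher number from compound 2 to compound 3 (0.17 log units; that floor lies within the scatter), the only shown instance of the change, with the reservation that it starts from a limit. Compound 4 is therefore estimated at about 7.5 uL/min, expected between 4 uL/min and 14 uL/min.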

Compound 4, intrinsic clearance in a liver preparation (reported as CLH), per the amount of preparation that the assay uses: < 5 uL/min
Compound 4 ended at the assay's limit (the forecaster's own chance of this, stated with the estimate: 30%); middle value at least 1.5-fold (0.17 log units) away from the limit.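

Compound 4 gives < 5 uL/min, a limit of the assay. Within the data shown here, compound 1 also sits at a limit, so no step from compound 1 to compound 4 can be read. From the compounds shown here alone, whether methyl in place of hydrogen changes clearance on the core of compound 1 stays open.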